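Butyl in place of dichlorophenyl on a piperazine-like ring

The source may report more compounds than this note shows. Statements on the series, on what has been measured and on what is new or still open speak of the compounds shown alone.

Measured compounds:
compound 1 `Cc1ncc([N+](=O)[O-])n1CC(O)CSC(=S)N1CCN(c2ccccc2)CC1` — > 5000000 nM
compound 2 `Cc1ncc([N+](=O)[O-])n1CC(O)CSC(=S)N1CCN(c2cccc(Cl)c2Cl)CC1` — 1000000 nM

In a toxicity assay on HeLa cells (Homo sapiens) for cytotoxicity, read by MTT assay, with a stated time of 24 h (a lower number here means a stronger inhibitor, a higher number a weaker inhibitor), compound 1 reaches only a limit, > 5000000 nM, which is the limit of > 5000000 nM in this assay, at which 1 of the 2 values shown sits. Compound 2 gives the only number shown, 1000000 nM. Among the measured compounds shown here, the step of an at least 5.0-fold lower number from compound 1 to compound 2 (0.69 log units; beyond the scatter) is the one measured change. Compound 3 `CCCCN1CCN(C(=S)SCC(O)Cn2c([N+](=O)[O-])cnc2C)CC1` differs from compound 2 by butyl in place of 2,3-dichlorophenyl on an amine nitrogen in a ring. For the measured compounds named here, no measured step covers an aryl-to-alkyl exchange at this nitrogen; the measured step only shows that the phenyl form sits at the limit. Compound 3 is therefore expected to be weaker, by about a 2.5-fold higher number from compound 2 to compound 3 (0.40 log units; beyond the scatter), with an estimated 2500000 nM between 800000 nM and 8000000 nM.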

Compound 3, half-maximal inhibitory concentration: 1910000 nM
Estimate against measurement, compound 3: 1.3-fold (0.12 log units) above, within the range that was stated.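

Butyl in place of 2,3-dichlorophenyl on this amine nitrogen gives a 1.9-fold higher number from compound 2 to compound 3 (0.28 log units; within the scatter) in this assay and so stays within the scatter. Butyl in place of phenyl gives an at least 2.6-fold lower number from compound 1 to compound 3 (0.41 log units; beyond the scatter) here, so an aromatic ring on this nitrogen is not needed for a measured number. The entry for compound 1 is a limit: the limit of > 5000000 nM in this assay, at which 1 of the 3 values shown sits.

The compounds shown leave open whether a longer chain, or an amine at the end of the butyl chain, would separate from compound 3 beyond the scatter. They also leave open how a single chlorine on the phenyl would read against compound 1.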